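The source may hold more compounds than are shown below. What is called first, only, known or untested is meant among the compounds shown, and "the series" means these compounds.

Measured in a functional assay on T47D cells (Homo sapiens) for cytotoxicity, read by MTT assay, with a stated time of 2 days; a higher number here means a weaker inhibitor, a lower number a stronger inhibitor:
- Compound 1 `CN(C)c1ccc2nc(-c3cccc4ccccc34)[nH]c(=O)c2c1`: > 50000 nM
- Compound 2 `Cc1ccc2c(=O)[nH]c(-c3ccccc3OC(F)(F)F)nc2c1`: > 50000 nM
- Compound 3 `Cc1ccc2nc(-c3cccc4ccccc34)[nH]c(=O)c2c1`: > 50000 nM

Each of these entries is a limit of the assay and not a number. Compound 3 therefore has no exact standing, only its limit of > 50000 nM. It shares that position with the other two compounds, as the limit of > 50000 nM in this assay, at which 3 of the 3 values shown sit, shows.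

The step followed here leads to compound 4 `O=c1[nH]c(-c2cccc3ccccc23)nc2ccc(N3CCCCC3)cc12`, which has not yet been measured. The change is piperidin-1-yl in place of methyl on an aromatic carbon, with piperidin-1-yl in place of methyl on an aromatic carbon.

Going by the values given here, one measured step bears on it: a step that the two limits leave unreadable from compound 1 to compound 3. That step exchanges dimethylamino for methyl on an aromatic carbon, but it gives no size to carry forward. Compound 1, the measured compound with dimethylamino, stays at its limit of > 50000 nM. With no readable step to draw on, no shift beyond the scatter is expected in this assay, in either direction, and a further limit is the most likely report.

The expected step is a number no higher from compound 3 to compound 4 (the limit leaves the size open). For compound 4 the estimated value is 50000 nM, with an expected range from 20000 nM to 100000 nM.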

Compound 4, half-maximal inhibitory concentration: > 50000 nM
Compound 4 was reported as a limit (the forecaster's own chance of this, stated with the estimate: 75%); the middle value sits exactly at the limit.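

In this assay compound 4 gives > 50000 nM, which is a limit of the assay and not a number. Going by these compounds alone, the steps from compound 1 and from compound 3 to compound 4 therefore cannot be read, and no new step follows: the limit of > 50000 nM in this assay, at which 4 of the 4 values shown sit. The compounds shown leave open whether any group at this aromatic carbon would give an exact value in this assay.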